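Para Methoxy in Place of Fluoro on a Piperidine Urea

The source may hold more compounds than are shown below. What is called first, only, known or untested is meant among the compounds shown, and "the series" means these compounds.

Measured compounds:
compound 1, `O=C(Nc1ccc2cc(CN3CCCC3)cnc2c1)N1CCC(c2ccccc2)CC1`; in an assay on CHO cells for displacement of a labelled ligand from melanin-concentrating hormone receptor 1 (Homo sapiens), read by scintillation counting, with a stated time of 1 h (on this read-out higher numbers stand for weaker inhibition and lower numbers for stronger inhibition), compound 1 gives 100 nM
compound 2, `O=C(Nc1ccc2cc(CN3CCCC3)cnc2c1)N1CCC(c2ccc(F)cc2)CC1`; in this assay compound 2 gives 35 nM

Compound 2 holds the lowest of the two numbers in this assay. Within the data shown here, its only neighbour is compound 1, and the step of a 2.9-fold lower number from compound 1 to compound 2 (0.46 log units; beyond the scatter) lies beyond the scatter, so compound 2 is the stronger binder of the pair.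

The unmeasured compound 3, `COc1ccc(C2CCN(C(=O)Nc3ccc4cc(CN5CCCC5)cnc4c3)CC2)cc1`, differs from compound 2 in one place: methoxy in place of fluoro on an aromatic carbon. Among the measured compounds shown here, the only measured step that bears on this place is a 2.9-fold lower number from compound 1 to compound 2 (0.46 log units; beyond the scatter), which shows that a substituent on that aromatic carbon is accepted and helps modestly. For the measured compounds named here, nothing measured tells how a methoxy compares with a fluoro there; the fluoro step is the sole guide, and it is a modest one.

Compound 3 is therefore expected to stay close to compound 2, with a step of a 1.4-fold higher number from compound 2 to compound 3 (0.15 log units; within the scatter) that should not clearly exceed the scatter. The estimate for compound 3 in this assay is 50 nM, with a range from 15 nM to 160 nM.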

Compound 3, half-maximal inhibitory concentration: 48 nM
Estimate against measurement, compound 3: 1.0-fold (0.02 log units) above; measured number inside the range.
By their numbers in this assay, from the lowest: compounds 2 and 3 (each within the scatter of the next); then compound 1.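

In this assay the result shows that the benefit of a substituent on this aromatic carbon, para to a large group, is not confined to fluoro: methoxy, with two heavy atoms against one and a hydrogen-bond acceptor that fluoro is not counted as having, also gives a 2.1-fold lower number from compound 1 to compound 3 (0.32 log units; beyond the scatter) here. The exchange of 4-fluorophenyl for 4-methoxyphenyl gives a 1.4-fold higher number from compound 2 to compound 3 (0.14 log units; within the scatter), so compound 2 and compound 3 cannot be told apart on this read-out, and the change in atoms and acceptor count carries no measurable penalty at this place. No independent measurement is available that would explain why these two different groups read alike.

The compounds shown leave open how far this tolerance extends on the same carbon, for instance to a nitrile, a hydroxy group, an amine or a longer chain such as ethoxy. They also leave open whether fluoro or methoxy would serve equally well on any other aromatic carbon of that ring, since every substituted compound here carries its group at this one place.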